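The compounds below may be only part of what the source reports. "The series", "measured", "known", "first", "only" and "open" are said of these compounds alone.

Compound 1 `CCCCCCCCCCCCCCNc1nc(SCc2ccc(C(F)(F)F)cc2)nc2ccccc12`: in a functional assay on HGC-27 cells (Homo sapiens) for cytotoxicity, read by MTT assay, with a stated time of 72 h (a higher number here means a weaker inhibitor, a lower number a stronger inhibitor), compound 1 gives > 50000 nM, which is a limit of the assay rather than a number.
Compound 2 `CCOc1ccccc1Nc1nc(SCc2ccc(C(F)(F)F)cc2)nc2ccccc12`: in this assay compound 2 gives > 50000 nM, again a limit.
Compound 3 `FC(F)(F)c1ccc(CSc2nc(Nc3cccc(Cl)c3)c3ccccc3n2)cc1`: in this assay compound 3 gives 19900 nM.

Among the measured compounds shown here, compound 3 therefore carries the only real number among the three; the other two sit at the limit of > 50000 nM in this assay, at which 2 of the 3 values shown sit. For the measured compounds named here, the single measured step within the set is an at least 2.5-fold lower number from compound 2 to compound 3 (0.40 log units; beyond the scatter), so swapping an alkoxy-bearing phenyl for a chlorine-bearing phenyl brought the number down out of the limit into a measurable range.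

Compound 4 `COc1ccc(Nc2nc(SCc3ccc(C(F)(F)F)cc3)nc3ccccc23)cc1OC` takes the opposite direction: 3,4-dimethoxyphenyl in place of 3-chlorophenyl on a nitrogen on an aromatic ring. Going by the values given here, compound 4 thus returns to an alkoxy-substituted phenyl, now with two such groups, and the step from compound 2 to compound 3 is the only comparison that bears on it. Its size suggests that reversing the alkoxy-to-chlorine exchange could lose much of what compound 3 gained, so the number for compound 4 is expected to rise, perhaps back toward the limit. For compound 4 in this assay the estimate is 40000 nM, within a range of 12000 nM to 120000 nM. This estimate means an expected step of a 2.0-fold higher number from compound 3 to compound 4 (0.30 log units; within the scatter), with a real chance that only a limit is reported.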

Compound 4, half-maximal inhibitory concentration: 17900 nM
Beside the measured number, compound 4's estimate is 2.2-fold (0.35 log units) above it; the range from low to high includes it.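

At this place, on a nitrogen on an aromatic ring, 3,4-dimethoxyphenyl and 3-chlorophenyl cannot be told apart in this assay, with a 1.1-fold lower number from compound 3 to compound 4 (0.05 log units; within the scatter). Alkoxy groups on the phenyl ring therefore do not by themselves keep a compound at the limit, as the earlier step alone might have suggested: the 3,4-dimethoxyphenyl group also gives a measurable number, with an at least 2.7-fold lower number from compound 2 to compound 4 (0.44 log units; beyond the scatter). The contrast is thus not simply oxygen against chlorine, and what sets the 2-ethoxyphenyl group apart can be stated only as a bound, as one end of each step from compound 2 is a limit and not a number: the limit of > 50000 nM in this assay, at which 2 of the 4 values shown sit.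

The compounds shown leave open whether a plain phenyl, a phenyl with a single methoxy group, or a phenyl carrying an amine or a carboxylic acid on this nitrogen would bring the number clearly lower than in compound 3 and compound 4. They also cannot separate the effect of where the alkoxy group sits on the ring from that of its being ethoxy rather than methoxy.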